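The compounds below may be only part of what the source reports. "The series", "measured", "known", "first", "only" and "open" are said of these compounds alone.

Compound 1 `CCCCCOCCCCCCC/C=C1\CC(CO)(COC(=O)C(C)(C)C)OC1=O` is one of three compounds built on a shared core that have been tested in a functional assay on K562 cells (Homo sapiens) for antiproliferative activity; a higher number here means a weaker inhibitor of growth, a lower number a stronger inhibitor of growth. Compound 1 gives 1.15 ug/mL, the highest of the three numbers. Compound 2 `CC(=O)OCCCCCCCCCCCCCCC/C=C1\CC(CO)(COC(=O)C(C)(C)C)OC1=O` gives 0.959 ug/mL, and the step of a 1.2-fold lower number from compound 1 to compound 2 (0.08 log units; within the scatter) lies within the scatter, so these two cannot be set in order. Compound 3 `COCCCCCCCCCCCCCCC/C=C1/CC(CO)(COC(=O)C(C)(C)C)OC1=O` gives 0.138 ug/mL, and the two values of compound 1 and compound 3 stand apart beyond the scatter.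

Compound 4 `CCCCCCCCC(O)CCCCCC/C=C1\CC(CO)(COC(=O)C(C)(C)C)OC1=O` differs from compound 1 in one place: 1-hydroxynonyl in place of (pentyloxy)methyl on a saturated chain carbon, six bonds along the chain from a double-bonded chain carbon. For the measured compounds named here, the only measured step that bears on this change is a 1.2-fold lower number from compound 1 to compound 2 (0.08 log units; within the scatter), which also reworked the outer part of the chain and moved the number only within the scatter. Going by the values given here, no measured step exchanges an ether for a hydroxyl, so the direction of any shift is not settled by the data. Both other compounds give lower numbers than compound 1, with compound 2 at 0.959 ug/mL and compound 3 at 0.138 ug/mL. A modest movement toward a lower number, not clearly beyond the scatter, is therefore expected, giving an estimated step of a 1.4-fold lower number from compound 1 to compound 4 (0.16 log units; within the scatter). Compound 4 is estimated at 0.8 ug/mL, with a range from 0.3 ug/mL to 2 ug/mL.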

Compound 4, concentration for 50% growth inhibition: 7.3 ug/mL
For compound 4 the middle estimate is 9.1-fold (0.96 log units) below the measured one, outside the stated range (above it).
By their numbers in this assay, from the lowest: compound 3; then compounds 2 and 1 (each within the scatter of the next); then compound 4.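

For the compounds shown here, putting 1-hydroxynonyl in place of (pentyloxy)methyl, on a saturated chain carbon, six bonds along the chain from a double-bonded chain carbon, gives in this assay a 6.3-fold higher number from compound 1 to compound 4 (0.80 log units; beyond the scatter), the first step between compounds differing in one place to lie beyond the scatter. The earlier step, a 1.2-fold lower number from compound 1 to compound 2 (0.08 log units; within the scatter), had shown no readable change, so compound 4 shows that this stretch of the chain does not tolerate every replacement and that growth inhibition can weaken through a change here. The change brings in a hydrogen-bond donor and also enlarges the group from 7 to 10 heavy atoms, and nothing available explains the shift or assigns it to either difference.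

The compounds shown leave open whether the hydroxyl or the longer chain carries the shift, a question that a plain nonyl group at this place could separate. They also leave open whether an amine, a ketone or a carboxylic acid on the same chain carbon would move the number in the same direction as the hydroxyl does.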